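The compounds below may be only part of what the source reports. "The series", "measured", "known", "first", "only" and "open" are said of these compounds alone.

Measured compounds:
compound 1 `Cc1cc(-c2nc(-c3ccc(CCC(=O)O)cc3C)no2)ccc1OC(C)C` — in a functional assay on CHO cells for agonist activity at sphingosine 1-phosphate receptor 5 (Homo sapiens), read by GTPgammaS binding (on this read-out lower numbers stand for an effect already at smaller amounts and higher numbers for an effect only at larger amounts of compound), compound 1 gives 210 nM
compound 2 `COc1cc(-c2nc(-c3ccc(CCC(=O)O)cc3C)no2)ccc1OC(C)C` — in this assay compound 2 gives 270 nM
compound 3 `Cc1cc(CCC(=O)O)ccc1-c1noc(-c2ccc(OC(C)C)c(C#N)c2)n1` — in this assay compound 3 gives 6.5 nM

Compound 3 stands lowest of the three numbers: a 32-fold lower number from compound 1 to compound 3 (1.51 log units; beyond the scatter) and a 42-fold lower number from compound 2 to compound 3 (1.62 log units; beyond the scatter) are both large steps, while a 1.3-fold higher number from compound 1 to compound 2 (0.11 log units; within the scatter) stays within the scatter. All three measured steps concern the exchange of a group on an aromatic carbon (methyl, methoxy, cyano); the part of the molecule carrying the isopropoxy group is unchanged across compounds 1, 2 and 3.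

Compound 4 `Cc1cc(CCC(=O)O)ccc1-c1noc(-c2ccc(OC(C)C(F)(F)F)c(C#N)c2)n1` differs from compound 3 by trifluoromethyl in place of methyl on a saturated chain carbon bound to an oxygen on an aromatic ring and a saturated chain carbon. Within the data shown here, no measured step touches this position, so nothing points to a direction for this change; the working expectation in this assay is no step beyond the scatter, with wider uncertainty than a repeated measurement would carry. Compound 4 is therefore estimated at 7 nM, with a range of 2.5 nM to 25 nM, an expected 1.1-fold higher number from compound 3 to compound 4 (0.03 log units; within the scatter).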

Compound 4, half-maximal effective concentration: 3.1 nM
Compound 4: the middle estimate sits 2.3-fold (0.35 log units) above what was measured; the measured number falls inside the stated range.
By their numbers in this assay, from the lowest: compound 4; then compound 3; then compounds 1 and 2 (each within the scatter of the next).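

In this assay, among these compounds, this is the first reading at the isopropoxy group, as the earlier steps changed only the group on the aromatic carbon. Trifluoromethyl in place of methyl on this saturated chain carbon gives a 2.1-fold lower number from compound 3 to compound 4 (0.32 log units; beyond the scatter) and so is a modest step beyond the scatter, with a larger group entering without any rise in the number. No measurement here accounts for this step.

Going by these compounds, it remains open how ethoxy, 2,2,2-trifluoroethoxy or a longer chain such as 1-(trifluoromethyl)propoxy would read in place of the isopropoxy group. On these data alone, it is also open whether 1-(trifluoromethyl)ethoxy gives a similar step with methyl or methoxy in place of cyano on the aromatic carbon, as in compound 1 and compound 2.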